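Methyl on the Sulfonyl Ring: Cytotoxicity Expected to Hold

This account rests on a few compounds, and the source may have more. Where it says the series, first, only, none or still open, it means among the compounds named here.

Compound 1 `O=C1/C(=C/c2cccnc2)CN(S(=O)(=O)c2ccccc2)C/C1=C\c1ccccc1F` was tested in an ADME assay on L02 cells (Homo sapiens) for cytotoxicity, read by MTT assay, with a stated time of 24 h (a lower number here means a stronger inhibitor, a higher number a weaker inhibitor), and gives 15300 nM. Compound 2 `Cc1ccc(S(=O)(=O)N2C/C(=C\c3cccnc3)C(=O)/C(=C/c3ccccc3F)C2)cc1` differs from compound 1 by methyl in place of hydrogen on an aromatic carbon; in this assay compound 2 gives 14900 nM, and the step is a 1.0-fold lower number from compound 1 to compound 2 (0.01 log units; within the scatter). Compound 3 `O=C1/C(=C/c2cccnc2)CN(S(=O)(=O)c2ccccc2)C/C1=C\c1ccccc1C(F)(F)F` differs from compound 1 by trifluoromethyl in place of fluoro on an aromatic carbon; in this assay compound 3 gives 12500 nM, and the step is a 1.2-fold lower number from compound 1 to compound 3 (0.09 log units; within the scatter). Compound 4 `Cc1ccc(S(=O)(=O)N2C/C(=C\c3cccnc3)C(=O)/C(=C/c3ccccc3C(F)(F)F)C2)cc1`, not yet measured, differs from compound 3 by methyl in place of hydrogen on an aromatic carbon, which is the same change as that from compound 1 to compound 2, in the same place. Because a 1.0-fold lower number from compound 1 to compound 2 (0.01 log units; within the scatter) stayed within the scatter, the step from compound 3 to compound 4 is expected to be no change at the digits printed from compound 3 to compound 4 (within the scatter). Compound 4 is therefore estimated at 12500 nM, with a range from 6500 nM to 25000 nM.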

Compound 4, half-maximal inhibitory concentration: 12300 nM
Compound 4: the middle estimate sits 1.0-fold (0.01 log units) above what was measured, and the stated range covers the measured number.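

In this assay, the change from phenylsulfonyl to (4-methylphenyl)sulfonyl gives a 1.0-fold lower number from compound 3 to compound 4 (0.01 log units; within the scatter), and this carries over from the earlier core without a difference beyond the scatter: the same change on two cores in this assay, a 1.0-fold lower number (0.01 log units; within the scatter) from compound 1 to compound 2 and a 1.0-fold lower number (0.01 log units; within the scatter) from compound 3 to compound 4, 1.0-fold (0.00 log units) apart, within the scatter of two such steps. Trifluoromethyl in place of fluoro, read on the methyl-bearing pair, gives a 1.2-fold lower number from compound 2 to compound 4 (0.08 log units; within the scatter), and it too matches its earlier step: the same change on two cores in this assay, a 1.2-fold lower number (0.09 log units; within the scatter) from compound 1 to compound 3 and a 1.2-fold lower number (0.08 log units; within the scatter) from compound 2 to compound 4, 1.0-fold (0.00 log units) apart, within the scatter of two such steps. Going by these compounds alone, all these steps lie within the scatter, so the two pairs show only that neither change shifts the number on these cores; they do not show how either change would behave on any other core or in any other test.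

The compounds shown leave open whether an amine or a carboxylic acid in place of the methyl would give a step beyond the scatter. They also leave open what a longer chain there would do.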